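Two Methoxy Groups in Place of a Methyl on the Benzyl Arm

The source may report more compounds than this note shows. Statements on the series, on what has been measured and on what is new or still open speak of the compounds shown alone.

Compound 1 `COc1cc(N(Cc2ccc(C)cc2)C(=O)CSc2nc3ccccc3s2)cc(OC)c1OC` stands only as a limit on the numbers shown. In a functional assay on PC-3 cells (Homo sapiens) for antiproliferative activity, read by MTT assay, with a stated time of 48 h (a lower number here means a stronger inhibitor, a higher number a weaker inhibitor), compound 1 gives > 80000 nM, a limit of the assay and not a number (the limit of > 80000 nM in this assay, at which 1 of the 3 values shown sits). The change to compound 4 `COc1ccc(CN(C(=O)CSc2nc3ccccc3s2)c2cc(OC)c(OC)c(OC)c2)cc1OC` is 3,4-dimethoxyphenyl in place of 4-methylphenyl on a saturated chain carbon bound to an amide-type nitrogen. For the measured compounds named here, two measured steps bear on it. Compound 2 `COc1ccc(CN(C(=O)CSc2nc3ccccc3s2)c2cc(OC)c(OC)c(OC)c2)cc1[N+](=O)[O-]` gives 26500 nM in this assay, and the step to it is an at least 3.0-fold lower number from compound 1 to compound 2 (0.47 log units; beyond the scatter). Compound 3 `COc1cc(N(Cc2ccccc2)C(=O)CSc2nc3ccccc3s2)cc(OC)c1OC` gives 54100 nM, and that step, an at least 1.4-fold lower number from compound 1 to compound 3 (0.16 log units; that floor lies within the scatter), stays within the scatter. Compound 4 carries a methoxy on the entering ring as compound 2 does, whose step an at least 3.0-fold lower number from compound 1 to compound 2 (0.47 log units; beyond the scatter) points downward, but it lacks the nitro group. One therefore expects compound 4 at 35000 nM, within 12000 nM to 90000 nM, an expected step of an at least 2.2-fold lower number from compound 1 to compound 4 (0.35 log units; beyond the scatter).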

Compound 4, half-maximal inhibitory concentration: > 80000 nM
Compound 4: no number, only a limit; the forecaster's own chance of this, stated with the estimate: 25%; middle value at least 2.2-fold (0.35 log units) from the limit.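

Compound 4 stands only as a limit of the assay, as compound 1 does, and the step between them cannot be read: the limit of > 80000 nM in this assay, at which 2 of the 4 values shown sit. Methoxy in place of nitro on an aromatic carbon gives an at least 3.0-fold higher number from compound 2 to compound 4 (0.47 log units; beyond the scatter), so among these compounds the lower number of compound 2 goes with the nitro group, not with the methoxy it shares with compound 4. With 3,4-dimethoxyphenyl in place of phenyl, the result is an at least 1.4-fold higher number from compound 3 to compound 4 (0.16 log units; that floor lies within the scatter), and that floor alone shows no loss beyond the scatter.

Going by these compounds, whether an amine or a carboxylic acid in place of the nitro group would keep the number of compound 2 stays open. On these data alone, how far compound 4 lies past its limit also stays open.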